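Quinoline acid series: isopropoxy in place of hydroxy

The compounds below may be only part of what the source reports. "The series", "measured", "known", "first", "only" and "open" are said of these compounds alone.

Compound 1 `Cc1nc(C(=O)O)nc2ccc(-c3ccc(OCc4c(-c5c(Cl)cccc5Cl)noc4C(C)C)cc3)cc12` gives 140 nM in a functional assay for agonist activity at Bile acid receptor (Homo sapiens), read by FRET; a higher number here means that more compound is needed for the effect, a lower number that less compound is needed.
Compound 2 `CC(C)c1onc(-c2c(Cl)cccc2Cl)c1COc1ccc(-c2ccc3nc(C(=O)O)cc(O)c3c2)cc1` gives 51 nM in this assay.

Compound 2 stands at the lowest number of the two; compound 1 sits beyond the scatter above it. The two differ in more than one place, so this gap is only noted. Compound 3 `CC(C)Oc1cc(C(=O)O)nc2ccc(-c3ccc(OCc4c(-c5c(Cl)cccc5Cl)noc4C(C)C)cc3)cc12` carries the change (isopropyl in place of hydrogen on an oxygen on an aromatic ring), isopropyl in place of hydrogen on an oxygen on an aromatic ring, read one bond further out as hydroxy to isopropoxy. For the measured compounds named here, no measured pair covers this change. The expected step of a 2.0-fold higher number from compound 2 to compound 3 (0.29 log units; within the scatter) is a modest rise in this assay, close to the scatter. Compound 3 is estimated at 100 nM, within 30 nM to 400 nM.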

Compound 3, half-maximal effective concentration: 40 nM
For compound 3 the middle estimate is 2.5-fold (0.40 log units) above the measured one; measured number inside the range.
By their numbers in this assay, from the lowest: compounds 3 and 2 (each within the scatter of the next); then compound 1.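

In this assay the step of a 1.3-fold lower number from compound 2 to compound 3 (0.11 log units; within the scatter) shows that this oxygen on the aromatic ring carries isopropyl in place of hydrogen with no readable shift. The hydroxy hydrogen is thus not needed here for a number in this range, at least in this pair. Nothing at hand speaks to the reason for this.

Open, from the compounds shown here alone, is whether methoxy, a longer alkoxy chain or an amine in place of isopropoxy holds the read-out. Also open, going by these compounds, is whether larger groups than isopropyl are tolerated on this oxygen.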